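Sulfanyl versus oxy linkers on the diamino core

The source may report more compounds than this note shows. Statements on the series, on what has been measured and on what is new or still open speak of the compounds shown alone.

Measured compounds:
compound 1 `Nc1cc(N)c2nc(-c3ccccc3)c(Sc3ccc(F)cc3)nc2c1` — < 100000 nM
compound 2 `Nc1cc(N)c2nc(-c3ccccc3)c(Oc3ccc(F)cc3)nc2c1` — 19100 nM
compound 3 `CCOC(=O)[C@H](CCC(=O)O)NC(=O)c1ccc(Oc2nc3cc(N)cc(N)c3nc2-c2ccccc2)cc1` — 7410 nM

In a functional assay on RXF 393 cells (Homo sapiens) for inhibition, read by sulforhodamine B assay, with a stated time of 48 h (on this read-out lower numbers stand for stronger inhibition of growth and higher numbers for weaker inhibition of growth), compound 2 gives 19100 nM, the highest of the two numbers; compound 3 gives 7410 nM, lower by a gap beyond the scatter. For compound 1 only a limit is recorded, (the limit of < 100000 nM in this assay, at which 1 of the 3 values shown sits). The step that the limit leaves unreadable from compound 1 to compound 2 is therefore unreadable in size.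

Compound 4 `COc1ccc(Sc2nc3cc(N)cc(N)c3nc2-c2ccccc2)cc1` is not yet measured. It differs from compound 2 by (4-methoxyphenyl)sulfanyl in place of 4-fluorophenoxy on an aromatic carbon. Going by the values given here, the only measured step that touches the same position, a step that the limit leaves unreadable from compound 1 to compound 2, gives no readable size, so no direction can be drawn from it. The step of a 1.2-fold lower number from compound 2 to compound 4 (0.08 log units; within the scatter) is expected to stay within the scatter. Compound 4 is therefore estimated at 16000 nM in this assay, between 4000 nM and 60000 nM.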

Compound 4, concentration for 50% growth inhibition: 3090 nM
Compound 4: the middle estimate sits 5.2-fold (0.71 log units) above what was measured; the whole stated range lies above it.
By their numbers in this assay, from the lowest: compound 4; then compound 3; then compound 2.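

Going by these compounds alone, at this aromatic carbon next to the ring nitrogen, (4-methoxyphenyl)sulfanyl in place of 4-fluorophenoxy gives the first readable step at this position in this assay: a 6.2-fold lower number from compound 2 to compound 4 (0.79 log units; beyond the scatter). The change replaces the linking atom and the ring substituent together, so the step cannot be assigned to either one alone. The steps from compound 1 cannot be read, as its value is a limit: the limit of < 100000 nM in this assay, at which 1 of the 4 values shown sits.

Still open, on these data alone, is which of the two changes carries the step, and whether an amine or an ethoxy group in place of the methoxy keeps the lower number.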